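A few compounds are considered here, and "the series" means these few. Any claim that something is new, unique, unknown or untested is made for them only; others in the source may bear on it.

Of the compounds shown here, three have been measured in a functional assay on MDA-MB-231 cells (Homo sapiens) for inhibition; on this read-out lower numbers stand for stronger inhibition and higher numbers for weaker inhibition. Compound 1 `O=C(/C=C/c1ccc(F)c(Br)c1)c1ccc(B(O)O)cc1` gives 9500 nM, compound 2 `O=C(/C=C/c1ccccc1)c1ccc[nH]1` gives 15000 nM, and compound 3 `O=C(O)COc1ccc(/C=C/C(=O)c2ccc(Cl)c(Cl)c2)cc1` gives 18000 nM. The number for compound 2 sits between those of the other two, and all three numbers lie within the usual scatter of one another, so none of them can be set apart from the rest.

Compound 4 `O=C(/C=C/c1ccc(B(O)O)cc1)c1ccc[nH]1` has not yet been measured in this assay. It differs from compound 2 in one place: a group of 3 heavy atoms (1 boron, 2 oxygen; no ring) in place of a hydrogen atom, on an aromatic carbon. No step beyond the usual scatter is expected for a 1.5-fold lower number from compound 2 to compound 4 (0.18 log units; within the scatter), because in this assay compound 1 gives 9500 nM while carrying a group of the same kind elsewhere in its structure. For compound 4 the estimated value in this assay is 10000 nM, with a range from 4000 nM to 30000 nM.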

Compound 4, half-maximal inhibitory concentration: 23000 nM
Estimate against measurement, compound 4: 2.3-fold (0.36 log units) below; low and high end bracket the measured number.
By their numbers in this assay, from the lowest: compounds 1, 2, 3 and 4 (each within the scatter of the next, the first and the last beyond it).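

Swapping a hydrogen atom for the group of 3 heavy atoms (1 boron, 2 oxygen), on an aromatic carbon, gives a 1.5-fold higher number from compound 2 to compound 4 (0.19 log units; within the scatter) in this assay. Within the data shown here, this pair is the first direct reading of this change, and at this position the group brings no step that can be told from the scatter. No measured information on the compounds bears on this result.

From the compounds shown here alone, whether an amine or a carboxylic acid in this same place would also stay within the scatter of compound 2 remains open. So does the outcome for the boron group on another aromatic carbon.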